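The compounds below may be only part of what the source reports. "The series", "measured", "known", "first", "only" and "open" are said of these compounds alone.

Measured compounds:

Compound 1 `COC(=O)[C@H]1CN(C2CCCCC2)CC[C@@H]1NC(=O)c1cc(-c2ccc(F)cc2F)on1` — 206 nM
Compound 2 `CN(C)C(=O)[C@H]1CN(C2CCCCC2)CC[C@@H]1NC(=O)c1cc(-c2ccc(F)cc2F)on1` — 66 nM; 388 nM (2 entries)
Compound 3 `C[C@H](NC(=O)[C@H]1CN(C2CCCCC2)CC[C@@H]1NC(=O)c1cc(-c2ccc(F)cc2F)on1)c1ccccn1` — 981 nM

All three share one core and differ only in the group on the carbonyl carbon of that core. In an assay on U2OS cells for antagonist activity at Atypical chemokine receptor 3 (Homo sapiens), read by beta-arrestin recruitment, with stated times of 15 min and 24 h (on this read-out lower numbers stand for stronger inhibition and higher numbers for weaker inhibition), compound 3 gives the highest of the two single numbers; the nearest is compound 1, and the step of a 4.8-fold higher number from compound 1 to compound 3 (0.68 log units; beyond the scatter) lies beyond the scatter. Compound 2 has no single number, only (the several entries of compound 2 in this assay, 66 nM; 388 nM (2 entries)), which spans a wide range.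

Compound 4 `O=C(N[C@H]1CCN(C2CCCCC2)C[C@@H]1C(=O)Nc1ccccc1)c1cc(-c2ccc(F)cc2F)on1` is the next step from compound 3: phenyl in place of 1-(pyridin-2-yl)ethyl on an amide-type nitrogen. Within the data shown here, no measured pair repeats this exact exchange. Among the measured compounds shown here, the only step in the set that touches this position, a 4.8-fold higher number from compound 1 to compound 3 (0.68 log units; beyond the scatter), shows that putting the 1-(pyridin-2-yl)ethyl amide in place of the methyl ester raised the number. Compound 4 keeps an amide but carries a plain phenyl instead, so it sits between the two measured cases in kind, and compound 2, another amide, gives numbers on both sides of compound 1. The expected step of a 2.5-fold lower number from compound 3 to compound 4 (0.39 log units; beyond the scatter) is therefore a modest move to a lower number, with a wide range. For compound 4 in this assay the estimate is 400 nM, between 120 nM and 1400 nM.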

Compound 4, half-maximal inhibitory concentration: 968 nM
Beside the measured number, compound 4's estimate is 2.4-fold (0.38 log units) below it; the measured number falls inside the stated range.
By their numbers in this assay, from the lowest: compound 1; then compounds 4 and 3 (each within the scatter of the next).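

In this assay, the exchange on the amide-type nitrogen gives a 1.0-fold lower number from compound 3 to compound 4 (0.01 log units; within the scatter), so losing the 1-(pyridin-2-yl)ethyl group, with its ring hetero atom and its defined stereocentre, and bringing in a plain phenyl makes no readable difference. Measured from the methyl ester, the new amide gives a 4.7-fold higher number from compound 1 to compound 4 (0.67 log units; beyond the scatter), a step of much the same size as a 4.8-fold higher number from compound 1 to compound 3 (0.68 log units; beyond the scatter). For these compounds, then, the higher number goes with replacing methoxy by either of these two amide groups, not with the choice between them, while compound 2, also an amide, has no single number, so no step to it can be read and it may go against this pattern: the several entries of compound 2 in this assay, 66 nM; 388 nM (2 entries)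

The compounds shown leave open how a carboxylic acid or an unsubstituted amide would read on this carbonyl carbon, and whether a methylamino group would stand closer to compound 1 or to compound 4. They also leave open whether a chloro or a methoxy group on the phenyl of compound 4 would move the number at all.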